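Urea aryl variation on the shared core

The source may hold more compounds than are shown below. What is called first, only, known or untested is meant among the compounds shown, and "the series" means these compounds.

Measured in an assay on isolated protein for inhibition of proto-oncogene tyrosine-protein kinase receptor Ret variant V804M (Homo sapiens), read by 33P incorporation, with stated times of 15 min and 40 min (a lower number here means a stronger inhibitor, a higher number a weaker inhibitor), so far:
compound 1 `O=C(Nc1ccc(Cl)cc1)Nc1ccc(Nc2ncnc3c2OCCN3)cc1` gives 2280 nM
compound 2 `COc1cccc(NC(=O)Nc2ccc(Nc3ncnc4c3OCCN4)cc2)c1` gives 5290 nM
compound 3 `Cc1cc(C)cc(NC(=O)Nc2ccc(Nc3ncnc4c3OCCN4)cc2)c1` gives 971 nM

Compound 3 stands lowest of the three, with a 2.3-fold lower number from compound 1 to compound 3 (0.37 log units; beyond the scatter) and a 5.4-fold lower number from compound 2 to compound 3 (0.74 log units; beyond the scatter). Compound 4 `O=C(Nc1ccc(Nc2ncnc3c2OCCN3)cc1)Nc1cc(Cl)cc(Cl)c1` differs from compound 3 by 3,5-dichlorophenyl in place of 3,5-dimethylphenyl on an amide-type nitrogen. Among the measured compounds shown here, no measured pair swaps methyl for chlorine at the same positions; the only step involving chlorine is a 2.3-fold lower number from compound 1 to compound 3 (0.37 log units; beyond the scatter), and that one also moves the substitution pattern. The measured steps are all modest, so compound 4 is expected to stay near compound 3, with a step of a 1.1-fold lower number from compound 3 to compound 4 (0.03 log units; within the scatter) that may fall within the scatter. Compound 4 is estimated at 900 nM, in the range 350 nM to 2500 nM.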

Compound 4, half-maximal inhibitory concentration: 1300 nM
For compound 4 the middle estimate is 1.4-fold (0.16 log units) below the measured one, within the range that was stated.
By their numbers in this assay, from the lowest: compounds 3, 4 and 1 (each within the scatter of the next, the first and the last beyond it); then compound 2.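

On the amide-type nitrogen, 3,5-dichlorophenyl and 3,5-dimethylphenyl cannot be told apart, with a 1.3-fold higher number from compound 3 to compound 4 (0.13 log units; within the scatter). The 3,5-dichlorophenyl group also cannot be separated from 4-chlorophenyl, with a 1.8-fold lower number from compound 1 to compound 4 (0.24 log units; within the scatter), whereas the gap from 3-methoxyphenyl remains, with a 4.1-fold lower number from compound 2 to compound 4 (0.61 log units; beyond the scatter). No measurement at hand offers an explanation for these readings. Still open, going by these compounds, is how an aryl group carrying an amine or a carboxylic acid would read here. Also open, on these data alone, is whether a cyclohexyl group in place of the aryl ring would keep numbers in this range.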